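Moving the aryl substituent on the pyrrole nitrogen

This account rests on a few compounds, and the source may have more. Where it says the series, first, only, none or still open, it means among the compounds named here.

Measured compounds:
compound 1 `COc1cc(C(=O)c2cn(-c3ccccc3C)cc2-c2ccccc2)cc(OC)c1OC` gives 2200 nM
compound 2 `COc1cc(C(=O)c2cn(-c3ccccc3Cl)cc2-c2ccccc2)cc(OC)c1OC` gives 1800 nM
compound 3 `COc1ccccc1-n1cc(C(=O)c2cc(OC)c(OC)c(OC)c2)c(-c2ccccc2)c1` gives 150 nM

In a functional assay on MCF7 cells (Homo sapiens) for cytotoxicity, read by MTT assay, with a stated time of 96 h (on this read-out lower numbers stand for stronger inhibition and higher numbers for weaker inhibition), compound 1 stands highest of the three numbers, and its nearest neighbour is compound 2 at a 1.2-fold lower number from compound 1 to compound 2 (0.09 log units; within the scatter), while its furthest is compound 3 at a 15-fold lower number from compound 1 to compound 3 (1.17 log units; beyond the scatter). Compound 4 `COc1cc(C(=O)c2cn(-c3ccc(Br)cc3)cc2-c2ccccc2)cc(OC)c1OC` has not yet been measured. It differs from compound 1 in one place: 4-bromophenyl in place of 2-methylphenyl on an aromatic nitrogen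

For the measured compounds named here, two measured steps bear on this change, both starting from compound 1. Exchanging the methyl of the 2-methylphenyl for chloro on the same aromatic carbon left the number unchanged within the scatter, a 1.2-fold lower number from compound 1 to compound 2 (0.09 log units; within the scatter). Exchanging it for methoxy moved the number a long way, a 15-fold lower number from compound 1 to compound 3 (1.17 log units; beyond the scatter). Going by the values given here, compound 4 carries bromine, a halogen like the chloro of compound 2, but the substituent now sits on a different carbon of the phenyl, and no measured step covers that shift. The halogen step suggests little movement, and the change of position adds uncertainty rather than a direction. Compound 4 is therefore expected to give 2000 nM in this assay, with a range from 700 nM to 6000 nM, which amounts to an estimated step of a 1.1-fold lower number from compound 1 to compound 4 (0.04 log units; within the scatter).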

Compound 4, half-maximal inhibitory concentration: 20 nM
Compound 4: the middle estimate sits 100-fold (2.00 log units) above what was measured; the measured number lies below the stated range.
By their numbers in this assay, from the lowest: compound 4; then compound 3; then compounds 2 and 1 (each within the scatter of the next).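

In this assay, for the compounds shown here, the aryl group on the aromatic nitrogen proved able to take the number well past the lowest of the earlier compounds, with a 7.5-fold lower number from compound 3 to compound 4 (0.88 log units; beyond the scatter) in the comparison with the 2-methoxyphenyl compound, and compound 4 now stands lowest of the four. A halogen on this phenyl is therefore not without effect in every placement: the 2-chlorophenyl had stayed within the scatter of the 2-methylphenyl, yet the 4-bromophenyl gives a 90-fold lower number from compound 2 to compound 4 (1.95 log units; beyond the scatter) and a 110-fold lower number from compound 1 to compound 4 (2.04 log units; beyond the scatter) in these two comparisons. No measurement in hand accounts for this gain.

The compounds shown leave open how much of the step belongs to bromine itself and how much to the carbon that carries it, as every step to compound 4 changes both at once. From the compounds shown here alone, it also remains unknown whether a plain phenyl on the nitrogen, or a chloro, methyl or methoxy group, an amine or a carboxylic acid on the carbon that carries bromine in the 4-bromophenyl, would give a similarly low number.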